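A few compounds are considered here, and "the series" means these few. Any claim that something is new, unique, unknown or untested is made for them only; others in the source may bear on it.

In a functional assay on KB cells (Homo sapiens) for inhibition, with a stated time of 72 h (a higher number here means a weaker inhibitor, a lower number a stronger inhibitor), compound 1 (`CCn1ccc2cc(C(=O)c3cc(OC)c(OC)c(OC)c3)ccc21`) gives 36 nM, compound 2 (`COc1cc(C(=O)c2ccc3c(ccn3C(C)C)c2)cc(OC)c1OC`) gives 1800 nM and compound 3 (`COc1cc(C(=O)c2ccc3c(ccn3CO)c2)cc(OC)c1OC`) gives 39 nM. Compound 3 thus stands level with compound 1 and far from compound 2. Compound 4 (`COc1cc(C(=O)c2ccc3c(ccn3CCC(=O)O)c2)cc(OC)c1OC`) has carboxymethyl in place of hydroxy on a saturated chain carbon bound to an aromatic nitrogen. Two measured steps changed that same carbon. One, a 1.1-fold higher number from compound 1 to compound 3 (0.03 log units; within the scatter), lay within the scatter, while the other, a 50-fold higher number from compound 1 to compound 2 (1.70 log units; beyond the scatter), was large. Neither introduces carboxymethyl, so the guidance is only indirect, but the large step suggests that this carbon does not tolerate every change. A clear step towards a weaker number is therefore expected in this assay, estimated as a 15-fold higher number from compound 3 to compound 4 (1.19 log units; beyond the scatter). Compound 4 is expected to give 600 nM, with an estimated range of 80 nM to 4500 nM.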

Compound 4, half-maximal inhibitory concentration: > 10000 nM
Compound 4: a limit, no number (the forecaster's own chance of this, stated with the estimate: 12%); middle value at least 16-fold (1.22 log units) from the limit.
By their numbers in this assay, from the lowest: compounds 1 and 3 (each within the scatter of the next); then compound 2. At a limit, above all of these: compound 4.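

In this assay compound 4 gives no number but a limit: the limit of > 10000 nM in this assay, at which 1 of the 4 values shown sits. Carboxymethyl in place of hydroxy brings an at least 250-fold higher number from compound 3 to compound 4 (2.40 log units; beyond the scatter) and carboxy in place of hydrogen brings an at least 270-fold higher number from compound 1 to compound 4 (2.44 log units; beyond the scatter), so a position that accepts hydroxymethyl as well as ethyl does not accept 2-carboxyethyl in this assay. This change costs even more than the earlier isopropyl, as 2-carboxyethyl in place of isopropyl brings an at least 5.5-fold higher number from compound 2 to compound 4 (0.74 log units; beyond the scatter). As far as these compounds go, whether the loss follows the carboxylic acid or the longer chain stays open. A methyl ester, an amide or a plain propyl group on the aromatic nitrogen would separate the two.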